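From 2-methoxyphenyl to 2-chlorophenyl: working notes

This account rests on a few compounds, and the source may have more. Where it says the series, first, only, none or still open, it means among the compounds named here.

Among the measured compounds shown here, compound 2 (`COc1ccccc1NC(=S)NC1CC(C)(C)Oc2ccc(Br)cc21`) gives 42000 nM in a functional assay on T98G cells (Homo sapiens) for inhibition, read by MTT assay, with a stated time of 72 h (on this read-out higher numbers stand for weaker inhibition and lower numbers for stronger inhibition), the highest number of the three measured so far. Its gaps to both other compounds lie beyond the scatter. Compound 1 (`CC1(C)CC(NC(=S)Nc2ccc(C#N)cc2)c2cc(F)ccc2O1`) gives 19000 nM and compound 3 (`CC1(C)CC(NC(=S)Nc2cccc([N+](=O)[O-])c2)c2cc(Cl)ccc2O1`) gives 4000 nM on the same read-out.

Compound 4 (`CC1(C)CC(NC(=S)Nc2ccccc2Cl)c2cc(Br)ccc2O1`) differs from compound 2 in one place: chloro in place of methoxy on an aromatic carbon, ortho to a large group (chloro in place of methoxy on an aromatic carbon). For the measured compounds named here, no measured pair isolates this change, so any expectation rests on the spread of the three values alone. With compound 2 at the top of that spread and compound 1 lower at 19000 nM in this assay, a modest move towards stronger inhibition is expected, though it may not clear the scatter by much. The estimated step is a 2.6-fold lower number from compound 2 to compound 4 (0.42 log units; beyond the scatter) on this read-out. For compound 4 the estimated value is 16000 nM with an expected range from 5000 nM to 45000 nM in this assay for now.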

Compound 4, half-maximal inhibitory concentration: 8000 nM
Compound 4: middle estimate off by 2.0-fold (0.30 log units), on the high side; the measured number falls inside the stated range.
By their numbers in this assay, from the lowest: compounds 3 and 4 (each within the scatter of the next); then compound 1; then compound 2.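

In this assay, among the compounds shown here, the only pair differing in one place gives a 5.3-fold lower number from compound 2 to compound 4 (0.72 log units; beyond the scatter) and so shows that, at this position on an aromatic carbon, ortho to a large group, chloro in place of methoxy moves the number towards stronger inhibition, beyond the scatter. The earlier compounds shown here could not show this, as they differ from each other in more than one place and no single change could be read from them. Nothing at hand accounts for the size or direction of this step.

Open, going by these compounds, is whether the step comes from the arrival of chloro or the departure of methoxy, and a methyl, a hydroxyl or an amine at the same place would bear on that. Also open, on these data alone, is whether the same change would give a similar step on the core of compound 1 or compound 3.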